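Chain extension in the series: compound 2 to compound 3

The source may report more compounds than this note shows. Statements on the series, on what has been measured and on what is new or still open speak of the compounds shown alone.

Values below come from a physicochemical assay for lipophilicity (a higher number here means a more lipophilic compound, a lower number a more polar compound), as the read-out.
- compound 1 `CCCCC1(c2ccccc2)NC(=O)NC1=O` gives 2.46 as its value
- compound 2 `CCCCCCCC1(c2ccccc2)NC(=O)NC1=O` gives 3.96 as its value

Among the measured compounds shown here, compound 2 (3.96) holds the higher of the two numbers, and its only measured neighbour is compound 1 (2.46), well beyond the scatter. Not yet measured is compound 3 `CCCCCCCCC1(c2ccccc2)NC(=O)NC1=O` on the same core. The change is methyl in place of hydrogen on a saturated chain carbon, seven bonds along the chain from a saturated ring carbon in words: methyl in place of hydrogen on a saturated chain carbon, seven bonds along the chain from a saturated ring carbon.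

For the measured compounds named here, one measured step bears on this: a number 1.50 log units higher from compound 1 to compound 2 (beyond the scatter) for propyl in place of hydrogen on a saturated chain carbon, four bonds along the chain from a saturated ring carbon. That step is large and upward. The new change extends the same chain, but methyl enters rather than propyl, so a smaller step in the same direction is expected in this assay here. A single step cannot show whether the trend holds at this chain length, so the range is kept wide. The estimated change is a modest rise (a number 0.50 log units higher from compound 2 to compound 3 (beyond the scatter)). Compound 3 is estimated at 4.46 (expected range 4.1 to 4.8).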

Compound 3, partition coefficient: 4.96
For compound 3 the middle estimate is 0.50 log units below the measured one, and the stated range ends below it.
By their numbers in this assay, from the lowest: compound 1; then compound 2; then compound 3.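

In this assay, the single added methyl gives a number 1.00 log units higher from compound 2 to compound 3 (beyond the scatter) and so still moves the number at this chain length, where the earlier pair reached only as far as compound 2. That modest step comes from one added methyl, whereas the propyl change gave a number 1.50 log units higher from compound 1 to compound 2 (beyond the scatter); taken together, the two extensions give a number 2.50 log units higher from compound 1 to compound 3 (beyond the scatter), and neither extension among these three compounds goes against the upward direction. Nothing at hand accounts for the size of the methyl step.

From the compounds shown here alone, whether the number keeps rising with a longer chain, and whether the step stays near the size of the methyl step, remains open, as two steps along one chain fix no rate. Also open, going by these compounds, is how an amine or a carboxylic acid on the same chain would compare with the plain alkyl chains of compound 1, compound 2 and compound 3 on the shared core.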